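Azetidine amide on the compound 1 scaffold: working notes

The compounds below may be only part of what the source reports. "The series", "measured", "known", "first", "only" and "open" are said of these compounds alone.

Within the data shown here, in a functional assay on MCF7 cells (Homo sapiens) for inhibition, read by sulforhodamine B assay, with a stated time of 72 h (on this read-out higher numbers stand for weaker inhibition of growth and lower numbers for stronger inhibition of growth), compound 1 `CNC(=O)/C=C/c1ccncc1-c1ccc2ccccc2c1` gives 9340 nM, the only actual number. Compound 2 `NNC(=O)CCc1ccncc1-c1ccc2ccccc2c1` reports only a limit, > 10000 nM. Compound 3 `CNC(=O)CCc1ccncc1-c1ccc2ccccc2c1` also reports only a limit, > 10000 nM. The series is thus bounded by the limit of > 10000 nM in this assay, at which 2 of the 3 values shown sit.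

Compound 4 `COC1CN(C(=O)/C=C/c2ccncc2-c2ccc3ccccc3c2)C1` keeps the core of compound 1 and carries 3-methoxyazetidin-1-yl in place of methylamino on a carbonyl carbon.

Two measured steps alter the chain rather than this group: an at least 1.0-fold higher number from compound 1 to compound 2 (0.02 log units; that floor lies within the scatter) and an at least 1.0-fold higher number from compound 1 to compound 3 (0.02 log units; that floor lies within the scatter). Both are floors within the scatter. Among the measured compounds shown here, the one step on an amide-type nitrogen, a step that the two limits leave unreadable from compound 2 to compound 3, cannot be read. For the measured compounds named here, no measured step therefore gives a size for this change, and no shift beyond the scatter is expected in either direction in this assay. The expectation rests on compound 1 at 9340 nM. A report of only a limit is about as likely as a number. The expected result is a 1.0-fold lower number from compound 1 to compound 4 (0.02 log units; within the scatter). For compound 4 the estimated value is 9000 nM, with an expected range of 3500 nM to 20000 nM.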

Compound 4, concentration for 50% growth inhibition: > 10000 nM
Compound 4 gave a limit, no number; the forecaster's own chance of this, stated with the estimate: 50%; middle value at least 1.1-fold (0.04 log units) from the limit.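

In this assay compound 4 reports only a limit, > 10000 nM. The step reads an at least 1.0-fold higher number from compound 1 to compound 4 (0.02 log units; that floor lies within the scatter), so 3-methoxyazetidin-1-yl in place of methylamino on a carbonyl carbon gives no readable gain in inhibition of growth, and any loss stays unsized. This is the first change at the carbonyl carbon with the double-bonded chain kept, and compound 1 remains the only compound with an actual number, leaving most of the series at the ceiling: the limit of > 10000 nM in this assay, at which 3 of the 4 values shown sit.

As far as these compounds go, whether a plain azetidin-1-yl or a dimethylamino group on the same carbonyl carbon would give a number under the limit remains open. So does the outcome for a carboxylic acid in place of the amide on the double-bonded chain, which the compounds shown do not address.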